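Swapping the amide phenyl for a difluorobenzyl group

A few compounds are considered here, and "the series" means these few. Any claim that something is new, unique, unknown or untested is made for them only; others in the source may bear on it.

Measured compounds:
- compound 1, `COc1ccc2c(=O)c(/C=C/C(=O)Nc3ccccc3)coc2c1`: > 100000 nM
- compound 2, `COc1cccc(NC(=O)/C=C/c2coc3cc(OC)ccc3c2=O)c1`: 19200 nM
- compound 3, `COc1ccc(CNC(=O)/C=C/c2coc3cc(OC)ccc3c2=O)cc1`: > 100000 nM

In a functional assay on HeLa cells (Homo sapiens) for inhibition, read by MTT assay, with a stated time of 48 h (on this read-out higher numbers stand for weaker inhibition and lower numbers for stronger inhibition), compound 1 gives only a limit of the assay, > 100000 nM, not a number. Compound 1 therefore shares its standing with one other compound, since (the limit of > 100000 nM in this assay, at which 2 of the 3 values shown sit). Compound 2 is the only one of the three with a real number, and an at least 5.2-fold lower number from compound 1 to compound 2 (0.71 log units; beyond the scatter).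

Compound 4, `COc1ccc2c(=O)c(/C=C/C(=O)NCc3ccc(F)cc3F)coc2c1`, differs from compound 1 at the amide nitrogen: 2,4-difluorobenzyl in place of phenyl on an amide-type nitrogen.

Going by the values given here, two measured steps touch this kind of change. From compound 1 to compound 3 a benzyl-type group also replaced the phenyl, but a step that the two limits leave unreadable from compound 1 to compound 3, because both values are limits. From compound 2 to compound 3, where a benzyl-type group replaced an aromatic ring attached directly to the nitrogen, an at least 5.2-fold higher number from compound 2 to compound 3 (0.71 log units; beyond the scatter). Compound 3, the closest benzyl amide to compound 4, sits at the limit.

In this assay compound 4 is therefore expected to give no readable number, with the step that the limit leaves unreadable from compound 1 to compound 4 expected to stay within the scatter. The estimate for compound 4 is 150000 nM, in a range from 50000 nM to 500000 nM.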

Compound 4, half-maximal inhibitory concentration: > 100000 nM
Compound 4 was reported as a limit; the forecaster's own chance of this, stated with the estimate: 80%; the middle value lies beyond the limit too.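

Compound 4 gives a limit of the assay, not a number (> 100000 nM). Going by these compounds alone, with compound 3, there are now two benzyl-type amides, one carrying 4-methoxyphenyl and the other 2,4-difluorophenyl on the saturated chain carbon bound to the amide-type nitrogen, and neither gives a number, so a second, quite different ring on that carbon does not yield a readable value; the only comparison that can be read sets the new group against the 3-methoxyphenyl amide (an at least 5.2-fold higher number from compound 2 to compound 4 (0.71 log units; beyond the scatter)). The steps to compound 4 from compound 1 and from compound 3 cannot be read because each of these three compounds sits at the same limit: the limit of > 100000 nM in this assay, at which 3 of the 4 values shown sit.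

The compounds shown leave open whether any benzyl-type amide on the shared core can give a real number in this assay and how far beyond the limit compound 3 and compound 4 truly lie. They also leave open what would happen with a longer chain in place of the 2,4-difluorobenzyl group, or with an amine or a carboxylic acid on its ring.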